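A few compounds are considered here, and "the series" means these few. Any claim that something is new, unique, unknown or untested is made for them only; others in the source may bear on it.

Compound 1 `O=C1NCCC12CCN(c1c(Cl)cncc1-c1ccoc1)CC2` and compound 2 `Cc1cc(-c2cncc(Cl)c2N2CCC3(CCNC3=O)CC2)sc1C=O` were both tested in a functional assay on MV4-11 cells (Homo sapiens) for inhibition, read by resazurin assay, with a stated time of 72 h; on this read-out higher numbers stand for weaker inhibition of growth and lower numbers for stronger inhibition of growth. In this assay, among the measured compounds shown here, compound 1 gives 750 nM, and compound 2 gives 2530 nM; compound 1 therefore holds the lower of the two numbers, the only measured step being a 3.4-fold higher number from compound 1 to compound 2 (0.53 log units; beyond the scatter). Compound 3 `Cn1cccc1-c1cncc(Cl)c1N1CCC2(CCNC2=O)CC1` differs from compound 1 by 1-methyl-1H-pyrrol-2-yl in place of furan-3-yl on an aromatic carbon. For the measured compounds named here, the one step that bears on this replaced the same furan-3-yl with another five-membered ring and raised the number modestly, so a step in the same direction, near or a little beyond the scatter, is expected. The expected step is a 1.6-fold higher number from compound 1 to compound 3 (0.20 log units; within the scatter). Compound 3 is thus estimated at 1200 nM, with a range from 450 nM to 3200 nM.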

Compound 3, concentration for 50% growth inhibition: 900 nM
Estimate against measurement, compound 3: 1.3-fold (0.12 log units) above; low and high end bracket the measured number.
By their numbers in this assay, from the lowest: compounds 1 and 3 (each within the scatter of the next); then compound 2.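

In this assay the change to 1-methyl-1H-pyrrol-2-yl gives a 1.2-fold higher number from compound 1 to compound 3 (0.08 log units; within the scatter) and so shows that this position accepts a second five-membered aromatic ring with 1 hetero atom, here bearing a methyl on its nitrogen. Set against the substituted thiophene, the same group gives a 2.8-fold lower number from compound 2 to compound 3 (0.45 log units; beyond the scatter) and thus shows that the higher number of compound 2 does not extend to every five-membered ring here. Nothing available explains these steps. Still open, from the compounds shown here alone, is how a phenyl ring or an amine would fare on this aromatic carbon, and whether the formyl or the methyl of compound 2 accounts for its number.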